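Swapping methoxy for chloro on the benzyl ring

The compounds below may be only part of what the source reports. "The series", "measured", "known", "first", "only" and "open" are said of these compounds alone.

Three measured compounds share a core and differ in the groups attached to it. Compound 1 `CNc1nc(-n2cc(-c3ccccc3)nn2)nc2c1ncn2[C@@H]1O[C@H](CO)[C@@H](O)[C@H]1O`, compound 2 `CNc1nc(-c2cn(Cc3cccc(OC)c3)nn2)nc2c1ncn2[C@@H]1O[C@H](CO)[C@@H](O)[C@H]1O` and compound 3 `CCNC(=O)[C@H]1O[C@@H](n2cnc3c(NC)nc(-n4cc(CC5CCCC5)nn4)nc32)[C@H](O)[C@@H]1O` were each tested in an assay on CHO cells for displacement of a labelled ligand from adenosine receptor A3 (Homo sapiens); on this read-out lower numbers stand for stronger inhibition and higher numbers for weaker inhibition. Compound 1 gives 14.9 nM, compound 3 gives 11.5 nM, and compound 2 gives 86.1 nM, the highest of the three numbers; its gaps to compound 1 and to compound 3 both lie beyond the usual scatter, so compound 2 is the weakest binder of this set. Compound 4 `CNc1nc(-c2cn(Cc3cccc(Cl)c3)nn2)nc2c1ncn2[C@@H]1O[C@H](CO)[C@@H](O)[C@H]1O` has not yet been measured in this assay. It differs from compound 2 in a single place: chloro in place of methoxy on an aromatic carbon. For the measured compounds named here, no measured pair shows this particular swap, so there is no directly comparable step to draw on. A change of this kind is expected to shift the number only modestly, if at all. For compound 4 an inhibition constant of about 60 nM is estimated, within a range from 20 nM to 200 nM. The step of a 1.4-fold lower number from compound 2 to compound 4 (0.16 log units; within the scatter) is expected to stay within the scatter or amount to a small drop.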

Compound 4, inhibition constant: 81.1 nM
Estimate against measurement, compound 4: 1.4-fold (0.13 log units) below, and the stated range covers the measured number.
By their numbers in this assay, from the lowest: compounds 3 and 1 (each within the scatter of the next); then compounds 4 and 2 (each within the scatter of the next).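

In this assay, replacing methoxy with chloro on the benzyl ring gives a 1.1-fold lower number from compound 2 to compound 4 (0.03 log units; within the scatter), so 3-methoxybenzyl and 3-chlorobenzyl cannot be told apart on this read-out. For the compounds shown here, this is the first direct comparison at this place, an aromatic carbon meta to a large group, and it shows that removing the oxygen of the methoxy, with the hydrogen-bond acceptor counted there, leaves the number within the scatter. No available data bear on why the two groups read alike.

Two groups cannot show how far this tolerance extends, so an amine, a carboxylic acid or a longer chain at this place could behave differently. The plain benzyl group, with only hydrogen here, would show whether the ring needs a substituent at this place at all.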